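This account rests on a few compounds, and the source may have more. Where it says the series, first, only, none or still open, it means among the compounds named here.

Within the data shown here, in a functional assay on MCF7 cells (Homo sapiens) for inhibition, read by sulforhodamine B assay, with a stated time of 48 h (a lower number here means a stronger inhibitor, a higher number a weaker inhibitor), only two compounds have been read so far, and they share much of their core. Compound 1 `COc1ccc(C(c2ccc(OCCO)cc2)c2cccc3ccccc23)c(OC)c1OC` gives > 20000 nM, which is a limit of the assay and not a number. Among the measured compounds shown here, compound 2 `COc1ccc(C(O)(C/C=C\c2ccccc2)c2cccc3ccccc23)c(OC)c1OC` gives 10200 nM, the only true number available. Compound 3 `COc1ccc(C(OCc2ccc(C)cc2)c2cccc3ccccc23)c(OC)c1OC` keeps the core of compound 1 and differs from it in one place, with (4-methylbenzyl)oxy in place of 4-(2-hydroxyethoxy)phenyl on a saturated chain carbon bound to two aromatic carbons. For the measured compounds named here, no measured pair of compounds differing in one place is available to gauge this exchange, so any forecast is loose. With compound 2 at 10200 nM as the only measured point of reference, a small move toward stronger inhibition is expected in this assay, and it may not clear the usual scatter. The expected size of the change is an at least 1.4-fold lower number from compound 1 to compound 3 (0.15 log units; that floor lies within the scatter). Compound 3 is estimated at 14000 nM, with an expected range of 5000 nM to 30000 nM.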

Compound 3, half-maximal inhibitory concentration: 10700 nM
Beside the measured number, compound 3's estimate is 1.3-fold (0.12 log units) above it; the measured number falls inside the stated range.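

At the saturated chain carbon bound to two aromatic carbons, the core of compound 1 now has a read value: in this assay compound 3, which carries (4-methylbenzyl)oxy at this place, gives 10700 nM. Among these compounds, the exchange of 4-(2-hydroxyethoxy)phenyl for (4-methylbenzyl)oxy gives an at least 1.8-fold lower number from compound 1 to compound 3 (0.27 log units; that floor lies within the scatter), so this single change can be placed on a scale for the first time, although the printed floor does not clear the usual scatter. The true size of the step remains unknown, and only a floor can be given, because one end of the step is a limit of the assay and not a number: the limit of > 20000 nM in this assay, at which 1 of the 3 values shown sits.

The exchange replaces one group with another that differs in several ways at once, including the count of hydrogen-bond donors and acceptors, so the compounds shown do not tell which difference accounts for the step. They also leave open how the number would respond to an amine, a carboxylic acid or a longer chain at this same place on the shared core.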